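This account rests on a few compounds, and the source may have more. Where it says the series, first, only, none or still open, it means among the compounds named here.

Compound 3 `COc1cc(Nc2nc(Cl)cc3c(-c4ccccc4)n[nH]c23)cc(OC)c1OC` is one of three compounds tested in a functional assay on Flp-In-CHO cells for antagonist activity at adenosine receptor A3 (Homo sapiens), read by cAMP accumulation, with a stated time of 30 min; on this read-out higher numbers stand for weaker inhibition and lower numbers for stronger inhibition. In this assay compound 3 gives 12.3 nM, the second highest of the three numbers. For the measured compounds named here, compound 1 `COc1cc(Nc2nc(Cl)cc3c(C(C)C)n[nH]c23)cc(OC)c1OC` gives 2.82 nM, and the only single-point step within the set, a 4.4-fold higher number from compound 1 to compound 3 (0.64 log units; beyond the scatter), concerns the exchange of isopropyl for phenyl on the shared core and not the chloro. Compound 2 `N#Cc1cc2c(-c3ccccc3)n[nH]c2c(Nc2ccccc2)n1` carries a nitrile where compound 3 carries a chloro and a different aniline as well; in this assay compound 2 gives 60.3 nM. Going by the values given here, no single-point step joins compound 2 to compound 3, so its value shows only that a compound lacking the chloro can sit well above compound 3 in this assay.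

Compound 4 `COc1cc(Nc2nccc3c(-c4ccccc4)n[nH]c23)cc(OC)c1OC` differs from compound 3 in one place: hydrogen in place of chloro on an aromatic carbon. Among the compounds with values here, no measured step bears directly on this change, and the one step on record alters a different part of the molecule, so it gives no guide to the size or direction of the effect. The expectation for compound 4 is therefore uncertain, with a modest rise in the number, a 3.3-fold higher number from compound 3 to compound 4 (0.51 log units; beyond the scatter), considered most likely. For compound 4 in this assay the estimate is 40 nM, with a range from 10 nM to 160 nM.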

Compound 4, half-maximal inhibitory concentration: 5.13 nM
Compound 4: middle estimate off by 7.8-fold (0.89 log units), on the high side, and the stated range ends above it.
By their numbers in this assay, from the lowest: compounds 1 and 4 (each within the scatter of the next); then compound 3; then compound 2.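

Hydrogen in place of chloro on this aromatic carbon, next to the ring nitrogen, gives a 2.4-fold lower number from compound 3 to compound 4 (0.38 log units; beyond the scatter) in this assay. For the compounds shown here, this is the first reading of this position, and it shows that, with phenyl on the shared core, the chloro is not required for a low number and that removing it strengthens inhibition rather than weakening it. No evidence accompanies the result, so the data give no account of why the step runs in this direction.

The compounds shown leave open how an amine, a methoxy group or a methyl group on this same carbon would read against compound 3 and compound 4, as this single step gives the effect of only one exchange at the position. They also leave open whether hydrogen in place of chloro would move the number in the same direction, and by a similar amount, with isopropyl in place of phenyl, as in compound 1, since the step rests on one pair of compounds that both carry phenyl.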